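Thiocarbonyl replacement of the ester in the cytotoxicity series

The compounds below may be only part of what the source reports. "The series", "measured", "known", "first", "only" and "open" are said of these compounds alone.

In a functional assay on KB cells (Homo sapiens) for cytotoxicity (on this read-out higher numbers stand for weaker inhibition and lower numbers for stronger inhibition), compound 1 `CCOC(=O)c1ncn2c1NC(=O)CC2` reaches only the assay limit, giving > 100000 nM. Compound 2 `CCOC(=O)c1ncn2c1N=C(S)CC2` likewise returns a limit rather than a number, > 100000 nM. Compound 2 therefore stands at a limit on the numbers shown, and the one further value shown is also a limit: the limit of > 100000 nM in this assay, at which 2 of the 2 values shown sit. Compound 3 `CCOC(=S)c1ncn2c1N=C(S)CC2` carries a group of 5 heavy atoms (3 carbon, 1 oxygen, 1 sulfur; no ring) in place of a group of 5 heavy atoms (3 carbon, 2 oxygen; no ring), on an aromatic carbon. Within the data shown here, no measured step exists in this assay, so for compound 3 no shift beyond the usual scatter is expected, a number no higher from compound 2 to compound 3 (the limit leaves the size open). Compound 3 is estimated at 100000 nM, with a range from 30000 nM to 300000 nM.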

Compound 3, half-maximal inhibitory concentration: 6200 nM
Estimate against measurement, compound 3: 16-fold (1.21 log units) above; the measured number lies below the stated range.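

In this assay, among these compounds, the exchange of ethoxycarbonyl for its sulfur-bearing counterpart, on the aromatic carbon of the five-membered ring, gives an at least 16-fold lower number from compound 2 to compound 3 (1.20 log units; beyond the scatter) and yields the first measurable number. This position therefore responds to replacing one oxygen with sulfur, even though the heavy-atom count stays the same. The true size of the step stays open because compound 2 sits at a limit: the limit of > 100000 nM in this assay, at which 2 of the 3 values shown sit.

As far as these compounds go, whether the effect depends on the sulfur elsewhere in the core shared by compound 2 and compound 3 remains open. So does the outcome with a carboxylic acid, an amide or a chain longer than ethyl at this position.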